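Solubility notes on compounds 1 to 4

The compounds below may be only part of what the source reports. "The series", "measured", "known", "first", "only" and "open" are said of these compounds alone.

Compound 1 `COc1c(F)ccc2c1c(NS(=O)(=O)c1ccc(Cl)s1)nn2Cc1cccc(CNC(C)=O)c1` was measured in a physicochemical assay for solubility, read by chemiluminescence, measured as kinetic solubility; a lower number here means a less soluble compound, a higher number a more soluble compound. In this assay compound 1 gives only a limit of the assay, >= 199 ug/mL. Compound 2 `COc1c(F)ccc2c1c(NS(=O)(=O)c1ccc(Cl)s1)nn2Cc1cccc(CNC(=O)C(C)(C)O)c1` differs from compound 1 by 1-hydroxy-1-methylethyl in place of methyl on a carbonyl carbon. In this assay compound 2 likewise gives only a limit, >= 174 ug/mL. The step that the two limits leave unreadable from compound 1 to compound 2 cannot be read in size, as both ends rest at limits, namely the limit of >= 199 ug/mL in this assay, at which 1 of the 3 values shown sits, and (the limit of >= 174 ug/mL in this assay, at which 1 of the 3 values shown sits). Compound 3 `COc1cc(F)cc2c1c(NS(=O)(=O)c1ccc(Cl)s1)nn2Cc1cccc(CNC(C)=O)c1` has the same atoms as compound 1 joined differently; the difference between the two cores is not broken down here. In this assay compound 3 also gives only a limit, >= 161 ug/mL, which is the limit of >= 161 ug/mL in this assay, at which 1 of the 3 values shown sits. Compound 4 `COc1cc(F)cc2c1c(NS(=O)(=O)c1ccc(Cl)s1)nn2Cc1cccc(CNC(=O)C(C)(C)O)c1` is not yet measured; it differs from compound 3 by 1-hydroxy-1-methylethyl in place of methyl on a carbonyl carbon, the same change as from compound 1 to compound 2, at the same place. Among the compounds with values here, all three values so far reach only limits. Compound 4 is therefore expected to sit at a limit as well, with an expected step that the limit leaves unreadable from compound 3 to compound 4. For compound 4 the expected value in this assay is 170 ug/mL, with a range from 110 ug/mL to 230 ug/mL.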

Compound 4, solubility: >= 198 ug/mL
Compound 4: only a limit was reported; the forecaster's own chance of this, stated with the estimate: 85%; at least 1.1-fold (0.06 log units) between middle value and limit.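

Compound 3 and compound 4 both stand at limits in this assay, and the step between them cannot be read in size. The compounds shown leave open where the true solubility of compound 1, compound 2, compound 3 and compound 4 lies, and whether 1-hydroxy-1-methylethyl in place of methyl on a carbonyl carbon changes it at all.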